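Swapping the amine side chain on a sulfamate scaffold

The source may hold more compounds than are shown below. What is called first, only, known or untested is meant among the compounds shown, and "the series" means these compounds.

Compound 3 `CN(CCCN1CCCCC1)c1cccc(C(=O)N2CCc3ccc(OS(N)(=O)=O)cc3C2)c1` stands second highest of three in an assay on HEK293 cells for inhibition of Steryl-sulfatase (Homo sapiens), tested at 1 uM (on this read-out lower numbers stand for a weaker effect and higher numbers for a stronger effect at the one concentration tested), where compound 3 gives 30.6%. Compound 1 `CCN(Cc1ccncc1)c1cccc(C(=O)N2CCc3ccc(OS(N)(=O)=O)cc3C2)c1` gives 52.8% and compound 2 `NS(=O)(=O)Oc1ccc2c(c1)CN(C(=O)c1cccc(N3CCCCC3)c1)CC2` gives 11.9%, so a number 22.2 percentage points lower from compound 1 to compound 3 (beyond the scatter) and a number 18.7 percentage points higher from compound 2 to compound 3 (beyond the scatter). Compound 4 `CC(C)CCN(CCC(C)C)c1cccc(C(=O)N2CCc3ccc(OS(N)(=O)=O)cc3C2)c1` alters the same aromatic carbon once more: diisopentylamino in place of methyl(3-(piperidin-1-yl)propyl)amino on an aromatic carbon. Both earlier exchanges at this carbon shifted the read-out beyond the scatter, and a number 40.9 percentage points lower from compound 1 to compound 2 (beyond the scatter) shows the widest swing seen among these three. A shift of similar size in either direction is therefore plausible for compound 4, and three compounds give no firm sign of which way. The expected step is a number 5.6 percentage points lower from compound 3 to compound 4 (within the scatter), a slight drop. Compound 4 is estimated at 25%, within a range from 5% to 55%.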

Compound 4, a percentage reported as inhibition, at one concentration (the size of the read-out at that concentration, not a potency): 75.9%
Compound 4: middle estimate off by 50.9 percentage points, on the low side; the measured number lies above the stated range.
By their numbers in this assay, from the lowest: compound 2; then compound 3; then compound 1; then compound 4.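

In this assay, diisopentylamino, an amine with two open chains and no ring, stands beyond the scatter above all three other groups at this aromatic carbon (a number 45.3 percentage points higher from compound 3 to compound 4 (beyond the scatter); a number 64 percentage points higher from compound 2 to compound 4 (beyond the scatter); a number 23.1 percentage points higher from compound 1 to compound 4 (beyond the scatter)). A ring in the side chain is therefore not needed for a high read-out here, nor is a second nitrogen. Nothing available explains the rise. Going by these compounds, whether chain length or branching matters stays open. Dipentylamino, with straight chains, and dibutylamino, with shorter ones, would help separate the two.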